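Taking the Nitro Group off Compound 3

The source may report more compounds than this note shows. Statements on the series, on what has been measured and on what is new or still open speak of the compounds shown alone.

Measured so far in an ADME assay on a cell-free system (plasma, Homo sapiens) for protein binding, read by LC-MS, with a stated time of 5 h, tested at 10 uM

Compound 1 `OC[C@H]1O[C@H](Oc2ccc(-n3ccc4ccccc43)cc2Cl)[C@@H](O)[C@@H](O)[C@@H]1O` gives 98%
Compound 2 `OC[C@H]1O[C@H](Oc2ccc(N3CCc4ccccc43)cc2)[C@@H](O)[C@@H](O)[C@@H]1O` gives 97%
Compound 3 `O=[N+]([O-])c1ccc2c(c1)CCN2c1ccc(O[C@H]2O[C@H](CO)[C@@H](O)[C@H](O)[C@@H]2O)c(Cl)c1` gives 99%

All three compounds are almost entirely bound, so small differences in these high numbers matter mainly for the small free portion. Compound 3 at 99% lies within the usual scatter of compound 1 at 98% while compound 2 at 97% has a larger unbound fraction, a gap beyond the scatter.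

Compound 4 `OC[C@H]1O[C@H](Oc2ccc(N3CCc4ccccc43)cc2Cl)[C@@H](O)[C@@H](O)[C@@H]1O` has not been measured. For the measured compounds named here, it is compound 3 with hydrogen in place of nitro on an aromatic carbon and no measured pair differs in one place only, so the size of this change has not been seen directly.

Compound 1 has no nitro and still gives 98% in this assay so only a small shift toward more free compound is expected, none beyond the scatter. The expected step is a 2.0-fold higher unbound fraction from compound 3 to compound 4 (0.30 log units; within the scatter) and this remains an estimate. For compound 4 the estimated value is 98% within an expected range from 96% to 99.5%.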

Compound 4, plasma protein binding in the plasma assay: 99%
Estimate against measurement, compound 4: 2.0-fold (0.30 log units) (unbound fraction) above; the measured number falls inside the stated range.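

In the plasma assay, the first direct view of hydrogen in place of nitro shows no change at the digits printed from compound 3 to compound 4 (within the scatter), so at this position the nitro group can go without a readable shift in plasma protein binding. Also in the plasma assay, chloro in place of hydrogen gives a 3.0-fold lower unbound fraction from compound 2 to compound 4 (0.48 log units; beyond the scatter), a step beyond the scatter, while 2,3-dihydro-1H-indol-1-yl in place of 1H-indol-1-yl gives a 2.0-fold lower unbound fraction from compound 1 to compound 4 (0.30 log units; within the scatter). In a physicochemical assay for lipophilicity, using the shake flask method, in phosphate buffer, measured as octanol-water partition, with a stated time of 2 h, at pH 7.4, tested at 1 uM (on this read-out lower numbers stand for lower lipophilicity and higher numbers for higher lipophilicity), compound 3 gives 1.9 and compound 4 gives 2.8, so the nitro change does register, and a clear rise in lipophilicity need not come with a readable change in binding: the measured distribution coefficient of compound 3, 1.9, and of compound 4, 2.8, a number 0.90 log units higher (beyond the scatter)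

Still open, on these data alone, is whether another group at this position, such as an amine or a carboxylic acid, would leave more of the compound free in the plasma assay. Also open, as far as these compounds go, is whether hydrogen in place of nitro would behave the same way on a compound without the chloro group.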